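A few compounds are considered here, and "the series" means these few. Any claim that something is new, unique, unknown or untested is made for them only; others in the source may bear on it.

Working notes on the sulfonamide series built on the shared core of compound 1 `COCC(=O)N1CCC(NS(=O)(=O)c2ccc(NC(=O)c3ccccc3C)c3ccccc23)CC1`, compound 2 `Cc1ccccc1C(=O)Nc1ccc(S(=O)(=O)NC2CCN(C(=O)CN)CC2)c2ccccc12` and compound 3 `Cc1ccccc1C(=O)Nc1ccc(S(=O)(=O)NC2CCN(C(N)=O)CC2)c2ccccc12`, which differ only in the group on the piperidine nitrogen. In an assay on L1.2 cells for binding affinity to C-C chemokine receptor type 8 (Homo sapiens) (on this read-out lower numbers stand for stronger inhibition and higher numbers for weaker inhibition), compound 1 gives 15.8 nM, compound 2 gives 4.1 nM and compound 3 gives 243 nM. Compound 3 thus stands at the highest number of the three: one step is a 15-fold higher number from compound 1 to compound 3 (1.19 log units; beyond the scatter) and the other, larger still, is a 59-fold higher number from compound 2 to compound 3 (1.77 log units; beyond the scatter). Both steps show that the group on the carbonyl carbon of this side chain moves the number strongly.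

Compound 4 `CCCNC(=O)N1CCC(NS(=O)(=O)c2ccc(NC(=O)c3ccccc3C)c3ccccc23)CC1` is the next member: propyl in place of hydrogen on an amide-type nitrogen, so the carbamoyl of compound 3 becomes propylcarbamoyl. Going by the values given here, no measured step in the set adds a chain on this amide-type nitrogen; the steps of a 15-fold higher number from compound 1 to compound 3 (1.19 log units; beyond the scatter) and a 59-fold higher number from compound 2 to compound 3 (1.77 log units; beyond the scatter) bear on it only in showing that this part of the molecule is sensitive and that compound 3 sits at the weak end. A chain of three heavy atoms at the carbonyl, as in compound 1, went with a lower number than compound 3 shows, so a lower number is expected for compound 4, though with wide uncertainty. The estimate for compound 4 in this assay is 50 nM, range 10 nM to 250 nM, i.e. an expected step of a 4.9-fold lower number from compound 3 to compound 4 (0.69 log units; beyond the scatter).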

Compound 4, inhibition constant: 77.4 nM
Beside the measured number, compound 4's estimate is 1.5-fold (0.19 log units) below it; the measured number falls inside the stated range.
By their numbers in this assay, from the lowest: compound 2; then compound 1; then compound 4; then compound 3.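

Going by these compounds alone, putting propyl in place of hydrogen on the amide-type nitrogen gives a 3.1-fold lower number from compound 3 to compound 4 (0.50 log units; beyond the scatter) in this assay and so shows for the first time that this nitrogen accepts a chain, with a lower number as the result. The change recovers only part of the ground, since propylamino in place of the other groups on the carbonyl carbon still leaves a 4.9-fold higher number from compound 1 to compound 4 (0.69 log units; beyond the scatter) and, by a wider margin, a 19-fold higher number from compound 2 to compound 4 (1.28 log units; beyond the scatter) as the step from the aminomethyl compound. Among these four compounds, a propyl chain on the urea-type side chain therefore does not match either the methoxymethyl or the aminomethyl group, and no measurement shown gives a reason for any of these steps.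

Going by these compounds, it remains open whether a longer chain such as butyl, or a shorter one such as methyl or ethyl, on this amide-type nitrogen would shift the number further from that of compound 4. On these data alone, it is equally open whether an amine at the end of the propyl chain would bring the number closer to that of compound 2.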